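A few compounds are considered here, and "the series" means these few. Any claim that something is new, unique, unknown or untested is made for them only; others in the source may bear on it.

For the measured compounds named here, compound 1 `C=CCC(N)(CO)CCc1ccc(OCCCCCCC)cc1` is one of two compounds measured in a functional assay on the whole organism (spleen, spleen) with Rattus norvegicus as the target (a higher number here means that more compound is needed for the effect, a lower number that less compound is needed), where compound 1 gives 3.1 mg/kg. Compound 2 `CCCCCCCOc1ccc(CC[C@@](N)(CO)CCC)cc1` gives 4.4 mg/kg in this assay, and the two numbers sit within the scatter of each other, as a 1.4-fold higher number from compound 1 to compound 2 (0.15 log units; within the scatter) shows. Compound 3 `CCCCCCCOc1ccc(CCC(N)(CO)CCO)cc1` differs from compound 1 by hydroxymethyl in place of vinyl on a saturated chain carbon, two bonds along the chain from an amine nitrogen. Going by the values given here, the only measured step, a 1.4-fold higher number from compound 1 to compound 2 (0.15 log units; within the scatter), also swapped a small group on a saturated chain carbon without moving the number beyond the scatter, so for compound 3 a step of about a 1.3-fold higher number from compound 1 to compound 3 (0.11 log units; within the scatter) is expected, which is none beyond the scatter. Compound 3 is therefore estimated at 4 mg/kg in this assay, within a range from 1.5 mg/kg to 11 mg/kg.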

Compound 3, dose for 50% inhibition: 0.055 mg/kg
For compound 3 the middle estimate is 73-fold (1.86 log units) above the measured one; the measured number lies below the stated range.
By their numbers in this assay, from the lowest: compound 3; then compounds 1 and 2 (each within the scatter of the next).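

In this assay the place two bonds along the chain from an amine nitrogen proves highly sensitive: hydroxymethyl in place of vinyl gives a 56-fold lower number from compound 1 to compound 3 (1.75 log units; beyond the scatter) on this measure. The comparison with compound 2 points the same way, with an 80-fold lower number from compound 2 to compound 3 (1.90 log units; beyond the scatter) as the matching step. Compounds 1 and 2 lie within the scatter of each other, so only the chain ending in a hydroxyl group stands apart.

Nothing measured here explains this step. As far as these compounds go, whether an amine, a carboxylic acid or a longer chain ending in a hydroxyl group would act the same way at this place stays open.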